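Moving the amino group onto a pyridine ring

The compounds below may be only part of what the source reports. "The series", "measured", "known", "first", "only" and "open" are said of these compounds alone.

In an assay on isolated protein for inhibition of leucine--tRNA ligase, cytoplasmic (Homo sapiens) (a lower number here means a stronger inhibitor, a higher number a weaker inhibitor), compound 1 `CC(C)C[C@H](N)C(=O)NS(=O)(=O)c1cccc(-c2cccc(N)n2)c1` gives 850 nM, and compound 2 `Cc1cc(-c2cccc(S(=O)(=O)NC(=O)[C@@H](N)CC(C)C)c2)ncn1` gives 2000 nM, the higher of the two numbers. The step of a 2.4-fold higher number from compound 1 to compound 2 (0.37 log units; beyond the scatter) shows that replacing the amino-bearing pyridine with the methyl-bearing pyrimidine weakened binding modestly. Compound 3 `CC(C)C[C@H](N)C(=O)NS(=O)(=O)c1cccc(-c2ccnc(N)c2)c1` differs from compound 2 by 2-aminopyridin-4-yl in place of 6-methylpyrimidin-4-yl on an aromatic carbon, restoring an amino-bearing pyridine in a different arrangement. Because the step of a 2.4-fold higher number from compound 1 to compound 2 (0.37 log units; beyond the scatter) went the other way, a modest improvement is expected, a 2.0-fold lower number from compound 2 to compound 3 (0.30 log units; within the scatter). Compound 3 is therefore estimated at 1000 nM in this assay, with a range from 400 nM to 3000 nM.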

Compound 3, half-maximal inhibitory concentration: 490 nM
Compound 3: the middle estimate sits 2.0-fold (0.31 log units) above what was measured; low and high end bracket the measured number.
By their numbers in this assay, from the lowest: compounds 3 and 1 (each within the scatter of the next); then compound 2.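

With the same heavy atoms on both sides, 2-aminopyridin-4-yl in place of 6-methylpyrimidin-4-yl gives a 4.1-fold lower number from compound 2 to compound 3 (0.61 log units; beyond the scatter) and adds one hydrogen-bond donor. Changing the ring arrangement from compound 1 gives a 1.7-fold lower number from compound 1 to compound 3 (0.24 log units; within the scatter), so the two amino-bearing pyridines cannot be separated in this assay, while each gives a lower number than compound 2. No evidence on the reason for this difference is available. Still open, on these data alone, is whether the amino group or the pyridine ring matters more. A hydroxyl or methyl group on the same pyridine would help separate the two.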